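The compounds below may be only part of what the source reports. "The series", "measured", "known", "first", "only" and "open" are said of these compounds alone.

In a functional assay on NCI-H460 cells (Homo sapiens) for antiproliferative activity, read by sulforhodamine B assay, with a stated time of 48 h (a higher number here means a weaker inhibitor, a lower number a stronger inhibitor), compound 1 (`O=C(CCCCCCN1C(=O)/C(=N\O)c2cc([N+](=O)[O-])ccc21)NO`) gives 7710 nM, compound 2 (`Cc1ccc2c(c1)/C(=N/O)C(=O)N2CCCCCCC(=O)NO`) gives 2090 nM and compound 3 (`CO/N=C1/C(=O)N(CCCCCCC(=O)NO)c2ccc(F)cc21`) gives 970 nM. Compound 3 therefore has the lowest number of the three and is the strongest inhibitor measured so far. It differs from compound 2 in more than one place, however, so the gap between their values cannot be assigned to any single group.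

The next compound, compound 4 (`CO/N=C1/C(=O)N(CCCCCCC(=O)NO)c2ccc(Br)cc21`), changes compound 3 in only one place: bromo in place of fluoro on an aromatic carbon. This puts bromo in place of fluoro on an aromatic carbon.

For the measured compounds named here, no measured pair compares these two groups directly. The closest evidence is a different swap on an aromatic carbon, methyl in place of nitro, which gives a 3.7-fold lower number from compound 1 to compound 2 (0.57 log units; beyond the scatter). Going by the values given here, that modest step is the only guide to how much such a swap can matter here, and it offers no direction for a change from fluoro to bromo. Since one single atom replaces another, a smaller shift than that one is expected, probably none beyond the scatter.

The expected change is a 1.1-fold lower number from compound 3 to compound 4 (0.03 log units; within the scatter). The estimated value for compound 4 is 900 nM, with an expected range of 400 nM to 2000 nM.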

Compound 4, half-maximal inhibitory concentration: 2900 nM
For compound 4 the middle estimate is 3.2-fold (0.51 log units) below the measured one; measured number above the stated range.
By their numbers in this assay, from the lowest: compound 3; then compounds 2 and 4 (each within the scatter of the next); then compound 1.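

This position does not treat the two atoms alike: in this assay, bromo in place of fluoro gives a 3.0-fold higher number from compound 3 to compound 4 (0.48 log units; beyond the scatter), although one heavy atom replaces one heavy atom and the counts of hydrogen-bond donors and acceptors stay the same. For the compounds shown here, the only earlier single-place step on an aromatic carbon, a 3.7-fold lower number from compound 1 to compound 2 (0.57 log units; beyond the scatter), came from a different pair of groups on a different compound, so this is the first direct evidence that exchanging fluoro for bromo matters here, and compound 3, with fluoro, remains the strongest inhibitor of the four. Nothing measured here bears on why the swap has this effect.

What chloro or a plain hydrogen at this same position would give remains open, so the compounds shown cannot tell whether fluoro is unusually favourable or bromo unusually unfavourable. Also open, on these data alone, is whether the step from fluoro to bromo would keep its direction and size with a free oxime in place of the methoxy-bearing one, or with a longer chain.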